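The source may report more compounds than this note shows. Statements on the series, on what has been measured and on what is new or still open speak of the compounds shown alone.

Measured so far in a functional assay on MCF7 cells (Homo sapiens) for antiproliferative activity, read by sulforhodamine B assay, with a stated time of 48 h; a higher number here means a weaker inhibitor of growth, a lower number a stronger inhibitor of growth:
Compound 1, `O=C(NCc1cn(Cc2ccc(F)cc2)nn1)c1cn(-c2ccccc2)nc1-c1ccc(F)cc1`, gives 55300 nM.
Compound 2, `O=C(NCc1cn(Cc2ccc(F)cc2)nn1)c1cn(-c2ccccc2)nc1-c1ccc(Cl)cc1`, gives 570 nM.

Compound 2 holds the lowest of the two numbers in this assay. Among the measured compounds shown here, its only neighbour is compound 1, and the single step between them, a 97-fold lower number from compound 1 to compound 2 (1.99 log units; beyond the scatter), is large and lies well beyond the scatter; it comes from nothing more than chloro in place of fluoro on an aromatic carbon.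

Compound 3, `COc1ccc(-c2nn(-c3ccccc3)cc2C(=O)NCc2cn(Cc3ccc(F)cc3)nn2)cc1`, has not yet been measured. It differs from compound 2 in one place: methoxy in place of chloro on an aromatic carbon.

For the measured compounds named here, the only measured step that bears on this position is a 97-fold lower number from compound 1 to compound 2 (1.99 log units; beyond the scatter). Going by the values given here, it shows that exchanging one small group on this ring can move the number a long way, but no measured compound carries methoxy there, so neither the direction nor the size of the new step can be read from the data. The step is therefore expected as an 8.8-fold higher number from compound 2 to compound 3 (0.94 log units; beyond the scatter), set toward a higher number, with a wide range on both sides. Compound 3 is expected to give about 5000 nM in this assay, within a range from 500 nM to 50000 nM.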

Compound 3, concentration for 50% growth inhibition: 460 nM
Beside the measured number, compound 3's estimate is 11-fold (1.04 log units) above it, and the stated range ends above it.
By their numbers in this assay, from the lowest: compounds 3 and 2 (each within the scatter of the next); then compound 1.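

In this assay, going from 4-chlorophenyl to 4-methoxyphenyl gives a 1.2-fold lower number from compound 2 to compound 3 (0.09 log units; within the scatter), so this assay does not separate these two groups, even though methoxy carries a hydrogen-bond acceptor and chloro does not. The earlier comparison could have suggested that chloro was something special at this position, but the new result shows otherwise: there is also a 120-fold lower number from compound 1 to compound 3 (2.08 log units; beyond the scatter), a large step of about the same size as a 97-fold lower number from compound 1 to compound 2 (1.99 log units; beyond the scatter). Among the three groups seen on this ring carbon, it is therefore fluoro that stands apart, while chloro and methoxy sit together at the stronger end of the growth-inhibition scale.

Nothing available here explains why fluoro stands apart from the other two groups, and three compounds are too few to suggest a reason. From the compounds shown here alone, it also remains open whether other groups at this place, such as an amine, a carboxylic acid or a longer chain like ethoxy, would fall with chloro and methoxy or with fluoro, and an unsubstituted ring carbon poses the same question.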